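A few compounds are considered here, and "the series" means these few. Any claim that something is new, unique, unknown or untested is made for them only; others in the source may bear on it.

Compound 2, `COc1cc2c(Oc3ccc(NC(=O)c4cn(-c5ccccc5)nn4)cc3F)ccnc2cc1OCCCN1CCN(C)CC1`, gives 180 nM in a functional assay on HT-29 cells (Homo sapiens) for cytotoxicity, read by MTT assay, with a stated time of 72 h; a higher number here means a weaker inhibitor, a lower number a stronger inhibitor. Compound 1, `COc1cc2c(Oc3ccc(NC(=O)c4cn(-c5c(C)cccc5C)nn4)cc3F)ccnc2cc1OCCCN1CCC(C)CC1`, gives 2450 nM in this assay .

Among the compounds with values here, compound 2 stands at the lower of the two numbers measured so far; compound 1, its only neighbour, lies beyond the scatter above it. The two compounds differ in two places at once, so their values alone cannot be split into separate contributions.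

Compound 3, `COc1cc2c(Oc3ccc(NC(=O)c4cn(-c5c(C)cccc5C)nn4)cc3F)ccnc2cc1OCCCN1CCN(C)CC1`, keeps the amine tail of compound 2 and carries 2,6-dimethylphenyl in place of phenyl on an aromatic nitrogen. This is the same aromatic group on the ring nitrogen that compound 1 bears, while the tail of compound 1 is different. Within the data shown here, no measured pair isolates this change. A move toward a higher number is expected because compound 1 gives 2450 nM with the same 2,6-dimethylphenyl, though the second difference between compound 1 and compound 2 leaves the share of this change open. The step of a 4.4-fold higher number from compound 2 to compound 3 (0.65 log units; beyond the scatter) is therefore expected to lie beyond the scatter, upward. Compound 3 is estimated at 800 nM, within the range 250 nM to 2500 nM.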

Compound 3, half-maximal inhibitory concentration: 2170 nM
Compound 3: the middle estimate sits 2.7-fold (0.43 log units) below what was measured; measured number inside the range.
By their numbers in this assay, from the lowest: compound 2; then compounds 3 and 1 (each within the scatter of the next).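

In this assay, the step for 2,6-dimethylphenyl in place of phenyl on an aromatic nitrogen can now be read alone, with the 4-methylpiperazin-1-yl tail held constant: a 12-fold higher number from compound 2 to compound 3 (1.08 log units; beyond the scatter), a large change for a swap that adds only the two methyl carbons. With the 2,6-dimethylphenyl group held constant, 4-methylpiperazin-1-yl in place of 4-methylpiperidin-1-yl on a saturated chain carbon gives a 1.1-fold lower number from compound 1 to compound 3 (0.05 log units; within the scatter), so in this pair the tail exchange does not move the number beyond the scatter, and the two contributions that compound 1 and compound 2 could not separate are now read one at a time. Nothing shown here gives a measured reason for the size of the aromatic step.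

From the compounds shown here alone, what the tail exchange does when phenyl, rather than 2,6-dimethylphenyl, sits on the aromatic nitrogen remains open, since the flat tail step is known only alongside the 2,6-dimethylphenyl group. Going by these compounds, it is also open whether the higher number follows methyl groups specifically, which a 2,6-difluorophenyl or 2,6-diethylphenyl group on the same nitrogen would help to tell.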